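Moving One Fluorine Around a Benzyl Group

A few compounds are considered here, and "the series" means these few. Any claim that something is new, unique, unknown or untested is made for them only; others in the source may bear on it.

In a functional assay on DU-145 cells (Homo sapiens) for cytotoxicity, read by MTT assay, with a stated time of 24 h (a higher number here means a weaker inhibitor, a lower number a stronger inhibitor), compound 1 `O=C1/C(=C/c2ccccc2F)CN(Cc2cn(Cc3ccccc3F)nn2)C/C1=C\c1ccccc1F` gives 10600 nM as its value. Compound 3 `COc1ccc(/C=C2\CN(Cc3cn(Cc4ccccc4Cl)nn3)C/C(=C\c3ccc(OC)cc3)C2=O)cc1` gives 17800 nM and lies within the usual scatter of compound 1, so the two cannot be told apart. Compound 2 `Cc1ccc(/C=C2\CN(C(=S)SCc3cn(Cc4ccccc4F)nn3)C/C(=C\c3ccc(C)cc3)C2=O)cc1` gives 80000 nM and stands beyond the scatter from compound 1, which makes it the clearly weaker inhibitor of that pair.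

Compound 4 `O=C1/C(=C/c2ccccc2F)CN(Cc2cn(Cc3ccc(F)cc3)nn2)C/C1=C\c1ccccc1F` has the same atoms as compound 1, joined differently. The change 4-fluorophenyl in place of 2-fluorophenyl on a saturated chain carbon bound to an aromatic nitrogen puts 4-fluorophenyl in place of 2-fluorophenyl on a saturated chain carbon bound to an aromatic nitrogen. Within the data shown here, no two measured compounds here differ in one place only, so nothing measured shows directly what such a swap does. In this assay no step beyond the scatter is therefore expected. The estimated step of a 1.1-fold higher number from compound 1 to compound 4 (0.05 log units; within the scatter) is small and stays within the scatter. Compound 4 is estimated at 12000 nM with an expected range from 5000 nM to 28000 nM once it is measured.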

Compound 4, half-maximal inhibitory concentration: 8700 nM
For compound 4 the middle estimate is 1.4-fold (0.14 log units) above the measured one; the range from low to high includes it.
By their numbers in this assay, from the lowest: compounds 4, 1 and 3 (each within the scatter of the next, the first and the last beyond it); then compound 2.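

Among these compounds, compound 4 gives the first direct reading at this position: with the rest of the molecule unchanged, 4-fluorophenyl in place of 2-fluorophenyl on a saturated chain carbon bound to an aromatic nitrogen gives a small step (a 1.2-fold lower number from compound 1 to compound 4 (0.09 log units; within the scatter)). In this assay the two compounds therefore cannot be told apart, so moving the fluorine around this benzyl group has no readable effect on the number here. Nothing measured on these compounds offers an explanation for this result.

Still open, on these data alone, is how 3-fluorophenyl would read at the same place, which would complete the set of fluorine positions. Also open, as far as these compounds go, is whether replacing the fluorine on this benzyl group with an amine or a carboxylic acid would move the number beyond the scatter.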